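The compounds below may be only part of what the source reports. "The series", "measured", "known", "first", "only" and "open" are said of these compounds alone.

Compound 1 `Cn1c(CN2CCC(c3ccccc3)CC2)nc2ccccc21` gives 200 nM in an assay on CHO cells with metabotropic glutamate receptor 2 (Homo sapiens) as the target, read by FLIPR; on this read-out lower numbers stand for an effect already at smaller amounts and higher numbers for an effect only at larger amounts of compound. Among the three measured compounds it stands second highest. Its nearest neighbour is compound 2 `Cn1c(CN2CCN(c3ccc(Cl)cc3F)CC2)nc2ccccc21`, which gives 126 nM in this assay, a gap within the scatter; the furthest is compound 3 `Cn1c(CN2CCN(c3ccc(C(F)(F)F)cn3)CC2)nc2ccccc21`, which gives 501 nM, a gap beyond the scatter. Compound 4 `Cn1c(CN2CCC(c3ccccn3)CC2)nc2ccccc21` has not yet been measured. It differs from compound 1 in one place: pyridin-2-yl in place of phenyl on a saturated ring carbon. Among the compounds with values here, no step between measured compounds isolates this change, so the expectation rests on compound 1 alone. The step from compound 1 to compound 4 is expected to be a 1.5-fold higher number from compound 1 to compound 4 (0.18 log units; within the scatter), not clearly beyond the scatter. Compound 4 is thus estimated at 300 nM, within 100 nM to 1000 nM.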

Compound 4, half-maximal effective concentration: > 3160 nM
Compound 4: a limit, no number; the forecaster's own chance of this, stated with the estimate: 5%; middle value at least 10-fold (1.02 log units) from the limit.
By their numbers in this assay, from the lowest: compounds 2 and 1 (each within the scatter of the next); then compound 3. At a limit, above all of these: compound 4.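

In this assay the change to pyridin-2-yl in place of phenyl on a saturated ring carbon gives an at least 15-fold higher number from compound 1 to compound 4 (1.19 log units; beyond the scatter) and shows that this position does not treat these two six-membered aromatic rings alike. The single ring nitrogen, which adds one hydrogen-bond acceptor, is the only difference between the two compounds. The result for compound 4 is a limit, not a number: the limit of > 3160 nM in this assay, at which 1 of the 4 values shown sits.

The compounds shown leave open whether pyridin-3-yl or pyridin-4-yl at this position would behave like phenyl or like pyridin-2-yl. On these data alone, the full size of the step also stays open.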